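A few compounds are considered here, and "the series" means these few. Any claim that something is new, unique, unknown or untested is made for them only; others in the source may bear on it.

Compound 1 (`COc1cc2c(cn1)Oc1ccc(NC(=O)c3ccc(Cl)cn3)cc1[C@@]21COC(N)=N1`) starts this account with a slow clearance reading. In an ADME assay on microsomes from liver (Rattus norvegicus) for metabolic stability, read by LC-MS, using NADPH, with a stated time of 30 min, tested at 1 uM (on this read-out higher numbers stand for fast clearance and lower numbers for slow clearance), compound 1 gives < 14 mL.min-1.g-1, which is a limit of the assay and not a number. Its true position is therefore known only from one side. Compound 2 (`NC1=N[C@@]2(CO1)c1cc(-c3cncc(C#CCO)c3)ccc1Oc1cnc(C3=CCOCC3)cc12`) carries different groups on the shared core and gives 46 mL.min-1.g-1 in this assay. It differs from compound 1 in more than one place, so the two values show only that this series can yield a measurable clearance.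

Compound 3 (`NC1=N[C@@]2(CO1)c1cc(NC(=O)c3ccc(Cl)cn3)ccc1Oc1cnc(Cl)cc12`) keeps the core and amide of compound 1 and changes a single group: chloro in place of methoxy on an aromatic carbon. This puts chloro in place of methoxy on an aromatic carbon, next to the ring nitrogen. Within the data shown here, no pair of measured compounds shows this exchange, so the expectation in this assay is necessarily a loose one. A modest upward move is expected, of a size close to the usual scatter, and the estimated step is an at least 1.4-fold higher number from compound 1 to compound 3 (0.15 log units; that floor lies within the scatter). Compound 3 is expected to give about 20 mL.min-1.g-1, with an estimated range from 9 mL.min-1.g-1 to 45 mL.min-1.g-1.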

Compound 3, intrinsic clearance in microsomes: < 14 mL.min-1.g-1
Compound 3 was reported as a limit (the forecaster's own chance of this, stated with the estimate: 35%); at least 1.4-fold (0.15 log units) between middle value and limit.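

Among these compounds, compound 1 and compound 3 both stand at a limit of the assay and not at a number, so no step between them can be read in this assay: the limit of < 14 mL.min-1.g-1 in this assay, at which 2 of the 3 values shown sit. The compounds shown leave open whether chloro in place of methoxy on an aromatic carbon changes clearance at all, and if so, in which direction and by how much.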